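A Smaller Group on the Amine of the Shared Core

The compounds below may be only part of what the source reports. "The series", "measured", "known", "first", "only" and "open" are said of these compounds alone.

Compound 1 `COc1cc(Oc2cccc(Nc3ccccc3)c2)cc(OC)c1CNCc1ccc(F)cc1` gives 2750 nM in a functional assay on HT-29 cells (Homo sapiens) for inhibition, read by MTT assay, with a stated time of 72 h (on this read-out higher numbers stand for weaker inhibition and lower numbers for stronger inhibition), the lowest of the two numbers shown, and compound 2 `COc1cc(Oc2cccc(Nc3ccccc3)c2)cc(OC)c1CNCCNC(C)=O` lies within the scatter of it at 3960 nM. Compound 3 `COc1cc(Oc2cccc(Nc3ccccc3)c2)cc(OC)c1CN(C)C` reaches only a limit of this assay, > 20000 nM. Compound 4 `COc1cc(Oc2cccc(Nc3ccccc3)c2)cc(OC)c1CNC1CC1` differs from compound 1 by cyclopropyl in place of 4-fluorobenzyl on an amine nitrogen. For the measured compounds named here, two measured steps bear on this change: a 1.4-fold higher number from compound 1 to compound 2 (0.16 log units; within the scatter), and an at least 7.2-fold higher number from compound 1 to compound 3 (0.86 log units; beyond the scatter), where the amine hydrogen is lost as well. Compound 4 keeps that hydrogen but carries only a three-membered ring, so a modest weakening is expected. For compound 4 the number in this assay is estimated at 6000 nM, between 2500 nM and 20000 nM, which means a 2.2-fold higher number from compound 1 to compound 4 (0.34 log units; beyond the scatter).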

Compound 4, half-maximal inhibitory concentration: 12300 nM
The estimate for compound 4 lay 2.1-fold (0.31 log units) below the measured number; measured number inside the range.
By their numbers in this assay, from the lowest: compounds 1 and 2 (each within the scatter of the next); then compound 4. At a limit, above all of these: compound 3.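

In this assay, a secondary amine alone does not hold the number at the level of compound 1 and compound 2: with cyclopropyl on the amine nitrogen there is a 4.5-fold higher number from compound 1 to compound 4 (0.65 log units; beyond the scatter), and also a 3.1-fold higher number from compound 2 to compound 4 (0.49 log units; beyond the scatter). Two quite different groups, 4-fluorobenzyl and 2-acetamidoethyl, thus both give lower numbers than the small ring. As far as these compounds go, compound 3 stands at a limit: the limit of > 20000 nM in this assay, at which 1 of the 4 values shown sits. From that limit the data give only an at least 1.6-fold lower number from compound 3 to compound 4 (0.21 log units; that floor lies within the scatter), and the true size of this step stays unknown.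

From the compounds shown here alone, whether a cyclohexyl ring, an unsubstituted benzyl group or a longer chain ending in an amine would match compound 1 remains open.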